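A few compounds are considered here, and "the series" means these few. Any claim that something is new, unique, unknown or untested is made for them only; others in the source may bear on it.

Measured so far:
- compound 1, `O=S1(=O)C=Cc2ccc(Nc3ccc(Cl)cc3)cc21`: 4440 nM
- compound 2, `O=S1(=O)C=Cc2ccc(Nc3ccc(Cl)c(Cl)c3)cc21`: 2470 nM
- compound 3, `O=S1(=O)C=Cc2cccc(Nc3ccc(Cl)cc3)c21`: 260 nM

All three compounds were tested in a functional assay on HCT-116 cells (Homo sapiens) for antiproliferative activity, read by MTT assay, with a stated time of 72 h; on this read-out lower numbers stand for stronger inhibition and higher numbers for weaker inhibition. Compound 1 and compound 2 share one core, and compound 2 carries one more chloro group than compound 1: chloro in place of hydrogen on an aromatic carbon. That single change gave a 1.8-fold lower number from compound 1 to compound 2 (0.25 log units; within the scatter), so the two numbers cannot be told apart with confidence.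

Compound 3 has the same atoms as compound 1, joined differently; the difference between the two cores is not broken down here. In this assay compound 3 gives the lowest number of the three: its gap to compound 2 and its gap to compound 1 are both beyond the usual scatter.

Compound 4, `O=S1(=O)C=Cc2cccc(Nc3ccc(Cl)c(Cl)c3)c21`, is not yet measured. It stands to compound 3 as compound 2 stands to compound 1: chloro in place of hydrogen on an aromatic carbon. The place of the entering chloro group is described in the same words in both cases, so this is the same change made on the core of compound 3. Going by the values given here, because the earlier step gave a 1.8-fold lower number from compound 1 to compound 2 (0.25 log units; within the scatter), only a small step is expected here too, and the expectation for compound 4 is a 1.4-fold lower number from compound 3 to compound 4 (0.16 log units; within the scatter), resting on the single earlier example. The estimated value for compound 4 in this assay is therefore 180 nM, with a likely range from 70 nM to 500 nM.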

Compound 4, half-maximal inhibitory concentration: 680 nM
For compound 4 the middle estimate is 3.8-fold (0.58 log units) below the measured one, outside the stated range (above it).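

In this assay, placing a second chloro group on the core of compound 3, ortho to the chloro group already there, gave a 2.6-fold higher number from compound 3 to compound 4 (0.42 log units; beyond the scatter), so on this core the added chloro group goes with a weaker result, and the step is a modest one. Set beside the earlier step, the result shows that this change does not carry over unchanged from one core to the other in this series: the same change on two cores in this assay, a 1.8-fold lower number (0.25 log units; within the scatter) from compound 1 to compound 2 and a 2.6-fold higher number (0.42 log units; beyond the scatter) from compound 3 to compound 4, 4.7-fold (0.67 log units) apart, beyond the scatter of two such steps. Going by these compounds alone, this shows only that the two steps differ; it rests on a single pair of compounds on each core, so it gives no reason for the difference and no rule for how the change would behave on any further core.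

The compounds shown carry only chloro groups on this six-membered aromatic ring, so it remains open whether a fluoro group, a methyl group, a methoxy group or an amine at the same place would also give different steps on the two cores. Within the data shown here, it also remains open whether the low number of compound 3, 260 nM, would survive such replacements of its single chloro group.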